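Difluoromethyl to chloro: what happens to the unbound share?

A few compounds are considered here, and "the series" means these few. Any claim that something is new, unique, unknown or untested is made for them only; others in the source may bear on it.

In an ADME assay on brain (Rattus norvegicus) for protein binding (a higher number here means a larger unbound share of the compound, a lower number a smaller unbound share), compound 1 `Cc1c(C(F)F)nnc2sc(C(=O)NC3CN(c4ncc(C(F)(F)F)cn4)C3)c(N)c12` gives 0.062 as the lower of two numbers, while compound 2 `Cc1nnc2sc(C(=O)NC3CN(c4ncc(C(F)(F)F)cn4)C3)c(N)c2c1C` gives 0.41 with methyl in place of difluoromethyl. Compound 3 `Cc1c(Cl)nnc2sc(C(=O)NC3CN(c4ncc(C(F)(F)F)cn4)C3)c(N)c12` awaits measurement and carries chloro in place of difluoromethyl on an aromatic carbon. For the measured compounds named here, only one measured step bears on this, and a 6.6-fold higher number from compound 1 to compound 2 (0.82 log units; beyond the scatter) brings methyl rather than chloro, so a smaller rise is expected here. The expected step is a 1.6-fold higher number from compound 1 to compound 3 (0.21 log units; within the scatter) and would stay within the scatter. For compound 3 the estimated value is 0.1 (range 0.04 to 0.25).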

Compound 3, unbound fraction: 0.037
Estimate against measurement, compound 3: 2.7-fold (0.43 log units) above, outside the stated range (below it).
By their numbers in this assay, from the lowest: compounds 3 and 1 (each within the scatter of the next); then compound 2.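

In this assay chloro in place of difluoromethyl gives a 1.7-fold lower number from compound 1 to compound 3 (0.22 log units; within the scatter) and stays within the scatter, whereas chloro in place of methyl gives an 11-fold lower number from compound 2 to compound 3 (1.04 log units; beyond the scatter) and lies beyond it. At this aromatic carbon, then, chloro and difluoromethyl cannot be told apart, and among these three groups only methyl stands clearly apart, with the larger unbound share. Nothing available explains why this position responds in this way.

Going by these compounds, whether methyl is unique here remains open. An ethyl, a methoxy or an amine on this carbon would show whether other groups share its larger unbound share.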